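This account rests on a few compounds, and the source may have more. Where it says the series, first, only, none or still open, it means among the compounds named here.

Measured so far in an assay for inhibition of serine/threonine-protein kinase PLK2 (Homo sapiens), read by FRET and Z'-LYTE, with a stated time of 1 h; on this read-out higher numbers stand for weaker inhibition and lower numbers for stronger inhibition:
compound 1 `CCCCNS(=O)(=O)c1ccc(Nc2ncc3c(n2)N(C2CCCC2)[C@H](CC)C(=O)N3C)cc1` — 19.9 nM
compound 2 `CC[C@@H]1C(=O)N(C)c2cnc(Nc3ccc(S(=O)(=O)Nc4ccccc4)cc3)nc2N1C1CCCC1` — 54.4 nM
compound 3 `CCCNC(=O)c1ccc2c(ccn2-c2ncc3c(n2)N(C2CCCC2)[C@H](CC)C(=O)N3C)c1` — 11.4 nM

Within the data shown here, compound 2 has the highest number of the three; the step of a 2.7-fold higher number from compound 1 to compound 2 (0.44 log units; beyond the scatter) is beyond the scatter, and compound 3, with no single-point step to compound 2, sits at a lower number still. Compound 4 `CC[C@@H]1C(=O)N(C)c2cnc(Nc3ccc(S(=O)(=O)NC4CCCC4)cc3)nc2N1C1CCCC1` is the next member: cyclopentyl in place of phenyl on a sulfonamide nitrogen. Among the measured compounds shown here, the only step that bears on it is a 2.7-fold higher number from compound 1 to compound 2 (0.44 log units; beyond the scatter), where an open-chain alkyl gave a lower number than phenyl at the same nitrogen. Cyclopentyl is again a saturated carbon group, so a modest fall back toward the number of compound 1 is expected. Compound 4 is therefore estimated at 25 nM in this assay, range 10 nM to 60 nM, an expected step of a 2.2-fold lower number from compound 2 to compound 4 (0.34 log units; beyond the scatter).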

Compound 4, half-maximal inhibitory concentration: 23.9 nM
Compound 4: the middle estimate sits 1.0-fold (0.02 log units) above what was measured; the range from low to high includes it.
By their numbers in this assay, from the lowest: compounds 3, 1 and 4 (each within the scatter of the next, the first and the last beyond it); then compound 2.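

In this assay the step of a 2.3-fold lower number from compound 2 to compound 4 (0.36 log units; beyond the scatter) on the sulfonamide nitrogen shows that a saturated carbon ring, and not only an open chain, gives a lower number than phenyl. With a 1.2-fold higher number from compound 1 to compound 4 (0.08 log units; within the scatter), cyclopentyl and butyl cannot be told apart, so of the three groups on this nitrogen, only phenyl stands apart. No data on hand account for the gap between phenyl and these two saturated groups. Still open, as far as these compounds go, is how a longer chain, a carboxylic acid or an amine on this nitrogen would read.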